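Moving three fluorines around a phenyl ring

The source may report more compounds than this note shows. Statements on the series, on what has been measured and on what is new or still open speak of the compounds shown alone.

Compound 1 `C=C[C@@](C)(/C=C/c1ccc(Nc2cc(F)c(F)cc2F)cc1)CCC=C(C)C` gives > 26000 nM
Compound 2 `C=C[C@@](C)(/C=C/c1ccc(Nc2cc(F)c(F)c(F)c2)cc1)CCC=C(C)C` gives > 26000 nM

In a functional assay on Raji cells (Homo sapiens) for cytotoxicity, with a stated time of 72 h (a higher number here means that more compound is needed for the effect, a lower number that less compound is needed), compound 2 gives > 26000 nM as a limit and not a number. Compound 1 gives > 26000 nM as a limit too. Compound 3 `C=C[C@@](C)(/C=C/c1ccc(Nc2c(F)cc(F)cc2F)cc1)CCC=C(C)C` carries 2,4,6-trifluorophenyl in place of 3,4,5-trifluorophenyl on a nitrogen on an aromatic ring, and 2,4,6-trifluorophenyl in place of 3,4,5-trifluorophenyl on a nitrogen on an aromatic ring sets out that swap. Among the compounds with values here, the one measured step is a step that the two limits leave unreadable from compound 1 to compound 2 and offers no size to carry over, so only the limit of > 26000 nM in this assay, at which 2 of the 2 values shown sit, remains as a guide. No change beyond the scatter is therefore expected in this assay in either direction. The expected size is a number no higher from compound 2 to compound 3 (the limit leaves the size open) as an estimate. Compound 3 is expected at 26000 nM with an estimated range from 10000 nM to 40000 nM in this measurement.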

Compound 3, half-maximal effective concentration: > 26000 nM
Compound 3 ended at the assay's limit (the forecaster's own chance of this, stated with the estimate: 85%); the middle value sits exactly at the limit.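

Compound 1, compound 2 and compound 3 all end at a limit and not a number in this assay, so no step between them can be read: the limit of > 26000 nM in this assay, at which 3 of the 3 values shown sit.

As far as these compounds go, whether moving the three fluorines changes the cytotoxicity at all remains open.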